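Moving a halogen on the aryl of a cytotoxic quinoline series

The compounds below may be only part of what the source reports. "The series", "measured", "known", "first", "only" and "open" are said of these compounds alone.

Compound 1 `COc1cc2c(Oc3ccc(NC(=O)c4nn(-c5ccccc5F)c(=O)c5ccccc45)cc3F)ccnc2cc1OCCCN1CCCC1`: 400 nM
Compound 2 `COc1ccc(-n2nc(C(=O)Nc3ccc(Oc4ccnc5cc(OCCCN6CCCC6)c(OC)cc45)c(F)c3)c3ccccc3c2=O)cc1`: 2360 nM
Compound 3 `COc1cc2c(Oc3ccc(NC(=O)c4nn(-c5ccc(F)cc5)c(=O)c5ccccc45)cc3F)ccnc2cc1OCCCN1CCN(C)CC1`: 320 nM

All three compounds were tested in a functional assay on HT-29 cells (Homo sapiens) for cytotoxicity, read by MTT assay, with a stated time of 72 h; on this read-out higher numbers stand for weaker inhibition and lower numbers for stronger inhibition. Compound 3 gives the lowest of the three numbers in this assay; its nearest neighbour is compound 1, whose value lies within the scatter of it, while compound 2 sits well beyond the scatter.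

Compound 4 `COc1cc2c(Oc3ccc(NC(=O)c4nn(-c5ccccc5Br)c(=O)c5ccccc45)cc3F)ccnc2cc1OCCCN1CCN(C)CC1` is the next compound in this series. It differs from compound 3 in one place: 2-bromophenyl in place of 4-fluorophenyl on an aromatic nitrogen. The ring that carries the change is a six-membered aromatic ring with two nitrogens, part of a fused system of two rings.

Within the data shown here, only one measured step touches the same aryl group: a 5.9-fold higher number from compound 1 to compound 2 (0.77 log units; beyond the scatter). There the group gained a methoxy and lost a fluorine, which is a different change from the one here. Compound 1 and compound 3 together show that a fluorine in either position on that aryl gives numbers within the scatter of each other, though these two compounds also differ in the basic amine.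

With a halogen kept on the aryl, the estimated step is a 1.3-fold higher number from compound 3 to compound 4 (0.12 log units; within the scatter), and compound 4 is expected to come in at 420 nM, between 150 nM and 1200 nM.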

Compound 4, half-maximal inhibitory concentration: 1190 nM
For compound 4 the middle estimate is 2.8-fold (0.45 log units) below the measured one; low and high end bracket the measured number.
By their numbers in this assay, from the lowest: compounds 3 and 1 (each within the scatter of the next); then compounds 4 and 2 (each within the scatter of the next).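

In this assay, swapping one halogenated aryl for another is not a neutral change: there is a 3.7-fold higher number from compound 3 to compound 4 (0.57 log units; beyond the scatter), even though a halogen stays on the ring. The two groups have the same counts of heavy atoms, hydrogen-bond donors and acceptors and the same lack of net charge, so those counts do not separate them, yet the numbers do differ. This step, however, changes the element and its place on the ring together, so it cannot say which of the two matters, and no measurement here offers an explanation for the difference.

A 4-bromophenyl on the same core as compound 3 would help to pull these two changes apart, since it would keep the halogen's place on the ring while changing only the element. On these data alone, how a plain phenyl or a 4-aminophenyl would behave on this aromatic nitrogen also remains open, as does whether the step seen here would hold with a different amine at the far end of the chain.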